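Returning a nitrogen-bearing side chain to the acylguanidine

The compounds below may be only part of what the source reports. "The series", "measured", "known", "first", "only" and "open" are said of these compounds alone.

Compound 1, `COc1ccc(Br)cc1CCc1c(F)cccc1C(=O)/N=C(\N)NCCCN1CCCCC1`, gives 3.2 nM in an assay for binding affinity to Melanocortin receptor 4 (Homo sapiens); a higher number here means a weaker inhibitor, a lower number a stronger inhibitor.
Compound 2, `COc1ccc(Br)cc1CCc1c(F)cccc1C(=O)/N=C(\N)NCC(C)C`, gives 770 nM in this assay.

Among the measured compounds shown here, compound 2 stands at the highest of the two numbers measured so far; its only neighbour is compound 1, and the single measured step between them, a 240-fold higher number from compound 1 to compound 2 (2.38 log units; beyond the scatter), shows how much was lost when the longer chain ending in a piperidine ring was cut back to a small branched group. Compound 3, `COc1ccc(Br)cc1CCc1c(F)cccc1C(=O)/N=C(\N)NCCCN1CCN(C)CC1`, differs from compound 2 by 2-(4-methylpiperazin-1-yl)ethyl in place of isopropyl on a saturated chain carbon bound to an amine nitrogen. This change runs in the opposite direction to the measured step: a short branched group gives way to a longer chain carrying a six-membered ring with two nitrogen atoms, much as in compound 1, where such a ring-bearing chain went with the low number. On that basis a large move downward is expected, a 130-fold lower number from compound 2 to compound 3 (2.11 log units; beyond the scatter), though the ring is not the same as in compound 1 and the size of the gain is uncertain. Compound 3 is therefore estimated at 6 nM, within a range of 1.5 nM to 30 nM.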

Compound 3, inhibition constant: 64 nM
The estimate for compound 3 lay 11-fold (1.03 log units) below the measured number; measured number outside the range, above it.
By their numbers in this assay, from the lowest: compound 1; then compound 3; then compound 2.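

In this assay, the step from the small branched group to the longer ring-bearing chain is large in its own right (a 12-fold lower number from compound 2 to compound 3 (1.08 log units; beyond the scatter)), so the low number at this position is not confined to the piperidine-bearing chain of compound 1. Among the compounds shown here, the ring at the end of the chain also counts, since exchanging only that ring, with the chain and the rest of the molecule unchanged, costs a large part of that ground (a 20-fold higher number from compound 1 to compound 3 (1.30 log units; beyond the scatter)), which places compound 3 clearly apart from both of its neighbours. Nothing available gives a measured reason why these two six-membered rings differ so much.

The compounds shown leave open whether the second ring nitrogen or the methyl group on it accounts for the loss from compound 1, a question that an unsubstituted piperazine or a morpholine ring at the end of the chain could help to separate. Also open, as far as these compounds go, is whether a ring is needed at all, as a simple dimethylamino group in its place would show, and how a shorter or longer chain would change the picture.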